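From furan-3-yl to 4-methylthiophen-2-yl

This account rests on a few compounds, and the source may have more. Where it says the series, first, only, none or still open, it means among the compounds named here.

Measured in an ADME assay (liver) for metabolic stability, with Liver microsome (Homo sapiens) as the target, using microsomes and NADPH, with a stated time of 30 min, tested at 1 uM; a higher number here means faster removal of the compound, a lower number slower removal:
compound 1 `Nc1ccc(S(=O)(=O)N2CCN(c3ncc(C(O)(C(F)(F)F)C(F)(F)F)cc3Br)CC2)cn1`: < 14 mL.min-1.g-1 (a limit)
compound 2 `CC(C)(C)n1cc(-c2cc(C(O)(C(F)(F)F)C(F)(F)F)cnc2N2CCN(S(=O)(=O)c3ccc(N)nc3)CC2)cn1`: 86 mL.min-1.g-1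
compound 3 `Nc1ccc(S(=O)(=O)N2CCN(c3ncc(C(O)(C(F)(F)F)C(F)(F)F)cc3-c3ccoc3)CC2)cn1`: < 14 mL.min-1.g-1 (a limit)

Compound 3 gives < 14 mL.min-1.g-1, which is a limit and not a number. Its place is therefore known only as the limit of < 14 mL.min-1.g-1 in this assay, at which 2 of the 3 values shown sit.

Compound 4 `Cc1csc(-c2cc(C(O)(C(F)(F)F)C(F)(F)F)cnc2N2CCN(S(=O)(=O)c3ccc(N)nc3)CC2)c1` carries 4-methylthiophen-2-yl in place of furan-3-yl on an aromatic carbon. Two measured steps at this same place bear on the change. The comparison with the bromo compound gives a step that the two limits leave unreadable from compound 1 to compound 3. The comparison with the 1-(tert-butyl)-1H-pyrazol-4-yl compound gives an at least 6.1-fold lower number from compound 2 to compound 3 (0.78 log units; beyond the scatter), so the group at this place can shift the read-out beyond the scatter. Compound 4 keeps a five-membered aromatic ring with 1 hetero atom, so a modest rise is expected, smaller than that step, and a result at the same limit remains possible. The estimate means an expected at least 2.0-fold higher number from compound 3 to compound 4 (0.30 log units; that floor lies within the scatter). For compound 4 the estimated value is 28 mL.min-1.g-1, with an expected range from 12 mL.min-1.g-1 to 70 mL.min-1.g-1.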

Compound 4, intrinsic clearance in microsomes: 29 mL.min-1.g-1
Compound 4: the middle estimate sits 1.0-fold (0.02 log units) below what was measured, within the range that was stated.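

In this assay, 4-methylthiophen-2-yl in place of furan-3-yl gives an at least 2.0-fold higher number from compound 3 to compound 4 (0.31 log units; beyond the scatter), and in place of bromo it gives an at least 2.0-fold higher number from compound 1 to compound 4 (0.31 log units; beyond the scatter), so a five-membered aromatic ring with 1 hetero atom at this place does not by itself hold the read-out at the limit. Against 1-(tert-butyl)-1H-pyrazol-4-yl, the same group gives a 3.0-fold lower number from compound 2 to compound 4 (0.47 log units; beyond the scatter), so the two numbers measured at this place now stand apart beyond the scatter. The low end stays unresolved, and the step between compound 1 and compound 3 cannot be read, as each of these two compounds gives only a limit: the limit of < 14 mL.min-1.g-1 in this assay, at which 2 of the 4 values shown sit.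

Compound 4 differs from compound 3 both in its hetero atom and in carrying a methyl group, and the compounds shown do not separate the two. As far as these compounds go, how an aminomethyl group or a morpholine ring at this place would read also stays open.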